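A few compounds are considered here, and "the series" means these few. Any claim that something is new, unique, unknown or untested is made for them only; others in the source may bear on it.

Within the data shown here, compound 2 `COc1cc2ncnc(Nc3cccc(C)c3)c2cc1OCCCCC(=O)Nc1ccc(S(N)(=O)=O)cc1` holds the only number in this set: in a functional assay on A549 cells (Homo sapiens) for antiproliferative activity, read by MTT assay, with a stated time of 72 h (on this read-out higher numbers stand for weaker inhibition and lower numbers for stronger inhibition), compound 2 gives 16000 nM. Compound 1 `COc1cc2ncnc(Nc3ccc(F)cc3)c2cc1OCCCCC(=O)Nc1ccc(S(N)(=O)=O)cc1` reaches only a limit there, as compound 1 gives > 40000 nM, (the limit of > 40000 nM in this assay, at which 1 of the 2 values shown sits). Among the measured compounds shown here, the single measured step, an at least 2.5-fold lower number from compound 1 to compound 2 (0.39 log units; beyond the scatter), put 3-methylphenyl in place of 4-fluorophenyl on the nitrogen of the shared core. Compound 3 `COc1cc2ncnc(Nc3ccccc3)c2cc1OCCCCC(=O)Nc1ccc(S(N)(=O)=O)cc1` differs from compound 2 by hydrogen in place of methyl on an aromatic carbon, that is, 3-methylphenyl to phenyl. For the measured compounds named here, the step from compound 1 to compound 2 exchanged two substituents on that ring at once rather than removing one, and no measured step shows the plain loss of a methyl. For compound 3 the expected change in this assay is therefore a 1.6-fold higher number from compound 2 to compound 3 (0.19 log units; within the scatter), a slight weakening or none beyond the scatter. Compound 3 is thus estimated at 25000 nM, with a range from 10000 nM to 60000 nM.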

Compound 3, half-maximal inhibitory concentration: > 40000 nM
Compound 3 gave a limit, no number; the forecaster's own chance of this, stated with the estimate: 35%; middle value at least 1.6-fold (0.20 log units) from the limit.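

Hydrogen in place of methyl gives an at least 2.5-fold higher number from compound 2 to compound 3 (0.39 log units; beyond the scatter), so in this assay the plain loss of this one methyl, on an aromatic carbon meta to a large group, is a change beyond the scatter, which the earlier exchange of two different substituents could not show. Compound 3 now shares the limit of compound 1, so the step between those two cannot be read, and phenyl and 4-fluorophenyl cannot be ordered: the limit of > 40000 nM in this assay, at which 2 of the 3 values shown sit. Compound 2 alone keeps a number, so the step on removing the methyl has a lower bound but no full size.

As far as these compounds go, it remains open whether this effect is specific to methyl or would also appear with ethyl, chloro or methoxy at the same place. A longer or shorter chain with the 3-methylphenyl group kept also remains an open question.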